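Swapping the Aryl Group on a Sulfonamide Nitrogen

A few compounds are considered here, and "the series" means these few. Any claim that something is new, unique, unknown or untested is made for them only; others in the source may bear on it.

Of the compounds shown here, two sharing one core have been tested so far. Compound 1 has the structure `O=C1NCCN1c1ccc(S(=O)(=O)Nc2ccc(F)cc2)cc1`. Within the data shown here, in a functional assay on MCF7 cells (Homo sapiens) for antiproliferative activity, read by sulforhodamine B assay, with a stated time of 48 h (on this read-out lower numbers stand for stronger inhibition and higher numbers for weaker inhibition), compound 1 gives 690 nM, the only actual number on record, so it serves as the reference point here. Compound 2, `CC(C)(C)c1cc(NS(=O)(=O)c2ccc(N3CCNC3=O)cc2)cc(C(C)(C)C)c1`, carries two tert-butyl groups on the ring attached to the sulfonamide nitrogen. For compound 2 this assay reports only a limit, > 1000 nM, and not a number; this is the limit of > 1000 nM in this assay, at which 1 of the 2 values shown sits. Compound 3, the next compound to be measured, has the structure `COc1cccc(NS(=O)(=O)c2ccc(N3CCNC3=O)cc2)c1`. It differs from compound 1 at one place: 3-methoxyphenyl in place of 4-fluorophenyl on a sulfonamide nitrogen. Among the measured compounds shown here, because no pair of measured compounds differs at only one place, no measured step is available to guide the expectation; the swap is between two small substituted phenyl rings, and the expectation is that compound 3 will land close to compound 1. The step of a 1.2-fold higher number from compound 1 to compound 3 (0.09 log units; within the scatter) is expected to be small, within the usual scatter or only slightly weaker. Compound 3 is therefore estimated at 850 nM, with a likely range from 300 nM to 3000 nM.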

Compound 3, half-maximal inhibitory concentration: 120 nM
The estimate for compound 3 lay 7.1-fold (0.85 log units) above the measured number; measured number below the stated range.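

In this assay, the swap of 4-fluorophenyl for 3-methoxyphenyl on the sulfonamide nitrogen gives a 5.8-fold lower number from compound 1 to compound 3 (0.76 log units; beyond the scatter). Among these compounds, this is the first pair on record that differs in only one place, and it shows that the number responds to this position even when one substituted phenyl ring simply replaces another. Among the compounds shown here, nothing measured so far gives a reason for this step.

The pair changes two things at once, the substituent on the ring and the place where it sits, and the compounds shown do not separate them: 3-fluorophenyl and 4-methoxyphenyl would each change only one of the two. From the compounds shown here alone, it also remains open how far the trend runs with other groups on this ring, such as an amine or a carboxylic acid, or with a longer chain in place of the methoxy group.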